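Cytotoxicity notes: chloro added to the phenylpiperazine arm

The source may hold more compounds than are shown below. What is called first, only, known or untested is meant among the compounds shown, and "the series" means these compounds.

The series shares one core with a piperazine-acetamide linker to an arylpiperazine. Compound 1 is `O=C(CN1CCN(c2ccc([N+](=O)[O-])cc2)CC1)N1CCN(c2nnc(-c3ccccc3)c(-c3ccccc3)n2)CC1`; compound 2 is `Cc1ccc(-c2nnc(N3CCN(C(=O)CN4CCN(c5ccccc5)CC4)CC3)nc2-c2ccc(C)cc2)cc1`. In an ADME assay on NIH3T3 cells (Mus musculus) for cytotoxicity, read by MTT assay, with a stated time of 24 h (on this read-out higher numbers stand for weaker inhibition and lower numbers for stronger inhibition), compound 2 is reported only as a limit, > 914000 nM, so no number exists for it. In this assay compound 1 is likewise reported only as a limit, > 886000 nM. For the measured compounds named here, both values shown are therefore limits; compound 2 cannot be placed against compound 1 by order, and no measured step is available.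

The next compound, compound 3, is `Cc1ccc(-c2nnc(N3CCN(C(=O)CN4CCN(c5ccccc5Cl)CC4)CC3)nc2-c2ccc(C)cc2)cc1`. It differs from compound 2 in one place: chloro in place of hydrogen on an aromatic carbon, that is, phenyl to 2-chlorophenyl on the arylpiperazine arm.

Going by the values given here, with no measured step to lean on and with compound 2 sitting at the limit of > 914000 nM in this assay, at which 1 of the 2 values shown sits, no step beyond the scatter is expected from this change in this assay. Compound 3 is expected to give 900000 nM, with a range from 300000 nM to 2000000 nM, most likely again reported as a limit. The expected step is an at least 1.0-fold lower number from compound 2 to compound 3 (0.00 log units; that floor lies within the scatter), that is, essentially none.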

Compound 3, half-maximal inhibitory concentration: > 859000 nM
Compound 3: only a limit was reported; the forecaster's own chance of this, stated with the estimate: 80%; the middle value does not contradict the limit.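

In this assay compound 3 is reported only as a limit, > 859000 nM. Compound 2 is also reported only as a limit, so no step can be read from compound 2 to compound 3. The compounds shown leave open whether phenyl to 2-chlorophenyl changes the cytotoxicity at all, and where any of the three compounds would fall as a measured number.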